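From Ethoxy to Methylsulfanyl on Compound 1

A few compounds are considered here, and "the series" means these few. Any claim that something is new, unique, unknown or untested is made for them only; others in the source may bear on it.

Compound 1 `CCOc1ccc(C2C(C3CC3)C(=O)N2c2cc(OC)c(OC)c(OC)c2)cc1`: 201 nM
Compound 2 `C=CC1C(=O)N(c2cc(OC)c(OC)c(OC)c2)C1c1ccc(SCC)cc1`: 320 nM
Compound 3 `COc1ccc(C2C(O)C(=O)N2c2cc(OC)c(OC)c(OC)c2)cc1O`: 5 nM

These three values come from a functional assay on HL-60 cells (Homo sapiens) for inhibition, read by resazurin assay, with a stated time of 72 h; a lower number here means a stronger inhibitor, a higher number a weaker inhibitor. Compound 1, at 201 nM, holds the second highest of the three numbers. Its nearest neighbour is compound 2, at 320 nM, and the gap between the two lies within the scatter. The furthest is compound 3, at 5 nM, whose much lower number lies well beyond the scatter.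

The next compound to be tested in this assay is compound 4 `COc1cc(N2C(=O)C(C3CC3)C2c2ccc(SC)cc2)cc(OC)c1OC`, which has not yet been measured. It departs from compound 1 in one place: methylsulfanyl in place of ethoxy on an aromatic carbon. In words, methylsulfanyl stands in place of ethoxy on an aromatic carbon, para to a large group, so that 4-ethoxyphenyl becomes 4-(methylsulfanyl)phenyl.

Among the compounds with values here, no measured pair of compounds isolates this change, so the data offer no direct precedent for its size or direction. The expectation therefore starts from compound 1 at 201 nM, and no shift beyond the scatter is anticipated. The estimated change is a 1.3-fold lower number from compound 1 to compound 4 (0.13 log units; within the scatter), a small move toward a lower number that would remain within the scatter. In this assay, the estimated value for compound 4 is 150 nM, with the measurement expected to fall between 50 nM and 450 nM.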

Compound 4, half-maximal inhibitory concentration: 279 nM
Compound 4: the middle estimate sits 1.9-fold (0.27 log units) below what was measured; measured number inside the range.
By their numbers in this assay, from the lowest: compound 3; then compounds 1, 4 and 2 (each within the scatter of the next).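

In this assay, within the data shown here, exchanging ethoxy for methylsulfanyl on an aromatic carbon, para to a large group, gives the first direct reading of this change: a 1.4-fold higher number from compound 1 to compound 4 (0.14 log units; within the scatter). On the core of compound 1, the 4-ethoxyphenyl and 4-(methylsulfanyl)phenyl forms therefore cannot be told apart by this read-out, even though the group goes from 3 heavy atoms to 2 and its oxygen is exchanged for sulfur. Nothing available accounts for this result or shows what lies behind it.

This single pair leaves open whether other groups at this position, such as an amine, a carboxylic acid or a longer chain like butoxy, would also leave the number within the scatter, and whether the same exchange would behave alike on a different core. Compound 1 and compound 4 differ from compound 3 in more than one place, so the compounds shown do not reveal which features go with the much lower number of compound 3, 5 nM.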